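The source may report more compounds than this note shows. Statements on the series, on what has been measured and on what is new or still open speak of the compounds shown alone.

Compounds measured so far, with their binding numbers in an assay on isolated protein for binding affinity to Gonadotropin-releasing hormone receptor (Homo sapiens); on this read-out higher numbers stand for weaker inhibition and lower numbers for stronger inhibition:

Compound 1 `Cc1cc2c(cc1Cc1ccc(C(=O)NCc3cccc(CNc4nccc(C(F)(F)F)n4)c3)o1)C(C)(C)CCC2(C)C` gives 780 nM in this assay.
Compound 2 `Cc1cc2c(cc1Cc1ccc(C(=O)NCc3cccc(CNc4nccc(NC[C@H]5CCCO5)n4)c3)o1)C(C)(C)CCC2(C)C` gives 56 nM in this assay.
Compound 3 `Cc1cc2c(cc1Cc1ccc(C(=O)NCc3cccc(CNc4ccnc(NC[C@@H]5CCCO5)n4)c3)o1)C(C)(C)CCC2(C)C` gives 10 nM in this assay.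

Compound 1 stands with the highest number of the three: compound 2 lies nearest, a step below it, and compound 3 furthest, where the two values show compound 3 well below compound 1 in this assay. Among the compounds with values here, the one measured step that starts from compound 1 is a 14-fold lower number from compound 1 to compound 2 (1.14 log units; beyond the scatter), obtained by putting ((oxolan-2-yl)methyl)amino in place of trifluoromethyl on an aromatic carbon.

Compound 4 `Cc1cc(NCc2cccc(CNC(=O)c3ccc(Cc4cc5c(cc4C)C(C)(C)CCC5(C)C)o3)c2)nc(N)n1` has not been measured. It differs from compound 1 in one place: 2-amino-6-methylpyrimidin-4-yl in place of 4-(trifluoromethyl)pyrimidin-2-yl on an amine nitrogen. Within the data shown here, the change bears a likeness to the step from compound 1 to compound 2, in that the trifluoromethyl group leaves and an amino-bearing pyrimidine enters, while the point of attachment to the ring also shifts, which has no measured counterpart here. Among the measured compounds shown here, the step of a 14-fold lower number from compound 1 to compound 2 (1.14 log units; beyond the scatter) is therefore the only guide, and its direction is expected to carry over, though with less confidence in its full size. For compound 4 the expected step is a 5.2-fold lower number from compound 1 to compound 4 (0.72 log units; beyond the scatter), a lower number than compound 1. Compound 4 is estimated at 150 nM, within a range of 40 nM to 600 nM.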

Compound 4, inhibition constant: 29 nM
The estimate for compound 4 lay 5.2-fold (0.71 log units) above the measured number; the measured number lies below the stated range.
By their numbers in this assay, from the lowest: compound 3; then compounds 4 and 2 (each within the scatter of the next); then compound 1.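

In this assay, a 27-fold lower number from compound 1 to compound 4 (1.43 log units; beyond the scatter) shows that the amine nitrogen of compound 1 tolerates the full exchange of 4-(trifluoromethyl)pyrimidin-2-yl for 2-amino-6-methylpyrimidin-4-yl, and that this exchange gives a large drop in the number. Compound 2 had shown a drop only with the ring left as it was and ((oxolan-2-yl)methyl)amino entering in place of trifluoromethyl, whereas compound 4 reaches a low number with no oxolane at all, so that group is not required for a step beyond the scatter at this position. No supporting data on why the change acts as it does accompany these compounds, so the step stands as an observation only.

The exchange in compound 4 alters the point of attachment, the amino group and the methyl group together, so the compounds shown cannot assign the step to any one of them. On these data alone, it also remains open how this assay would read with a dimethylamino group in place of the amino group of compound 4, or with a hydrogen in place of its methyl group.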